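The source may hold more compounds than are shown below. What is called first, only, known or untested is meant among the compounds shown, and "the series" means these compounds.

Compound 1 `C[C@]1(CN2CCc3nc(-c4ccc(F)cc4)nnc3C2)Cn2cc([N+](=O)[O-])nc2O1` has no usable result in an ADME assay on Vero cells (Chlorocebus sabaeus) for cytotoxicity, read by MTT assay, with a stated time of 72 h; a lower number here means that less compound is tolerated, a higher number that more compound is tolerated; for compound 1 the entry reads "not determined" (no result reported). Compound 2 `C[C@]1(CN2CCc3nc(-c4cccc(F)c4)ccc3C2)Cn2cc([N+](=O)[O-])nc2O1` reached only the assay limit: in this assay compound 2 gives > 32 ug/mL, a limit rather than a number, as shown by the limit of > 32 ug/mL in this assay, at which 1 of the 2 values shown sits. Compound 3 `C[C@]1(CN2CCc3nc(-c4ccc(F)c(Cl)c4)ccc3C2)Cn2cc([N+](=O)[O-])nc2O1` carries 3-chloro-4-fluorophenyl in place of 3-fluorophenyl on an aromatic carbon. For the measured compounds named here, no step between measured compounds is available, so the change is expected to move tolerance by nothing beyond the usual scatter, a step of a number no higher from compound 2 to compound 3 (the limit leaves the size open) being expected. Compound 3 is therefore estimated at 32 ug/mL, within 16 ug/mL to 64 ug/mL, most likely again reported only as a limit.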

Compound 3, half-maximal cytotoxic concentration: > 32 ug/mL
Compound 3: a limit, no number; the forecaster's own chance of this, stated with the estimate: 70%; the middle value sits exactly at the limit.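

In this assay compound 2 and compound 3 both end at a limit, so no step between them can be read: the limit of > 32 ug/mL in this assay, at which 2 of the 3 values shown sit.

The compounds shown leave open whether 3-chloro-4-fluorophenyl in place of 3-fluorophenyl changes tolerance at all.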